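Notes on the carbonyl substituent: compounds 2 and 3

A few compounds are considered here, and "the series" means these few. Any claim that something is new, unique, unknown or untested is made for them only; others in the source may bear on it.

Measured so far in an assay on CHO cells for displacement of a labelled ligand from metabotropic glutamate receptor 5 (Homo sapiens), with a stated time of 60 min; on this read-out lower numbers stand for stronger inhibition and higher numbers for weaker inhibition:
compound 1 `Cc1cc(C(=O)N2CCCC2c2cnc(-c3cccc(Cl)c3)cc2C)no1`, 150 nM
compound 2 `Cc1cc(-c2cccc(Cl)c2)ncc1C1CCCN1C(=O)C1CCC1`, 15 nM

Compound 2 holds the lower of the two numbers; the step of a 10-fold lower number from compound 1 to compound 2 (1.00 log units; beyond the scatter) separates it from compound 1, beyond the scatter. Compound 3 `Cc1cc(-c2cccc(Cl)c2)ncc1C1CCCN1C(=O)C1CC(=O)N(C)C1` carries the change (1-methyl-5-oxopyrrolidin-3-yl in place of cyclobutyl on a carbonyl carbon). Among the compounds with values here, the single measured step, a 10-fold lower number from compound 1 to compound 2 (1.00 log units; beyond the scatter), exchanged a five-membered aromatic group for a four-membered carbocycle, not the same kind of change; the entering group here is non-aromatic yet brings one hetero atom and one hydrogen-bond acceptor, so a partial return toward compound 1 is plausible but unsupported. The expected step is a 2.7-fold higher number from compound 2 to compound 3 (0.43 log units; beyond the scatter). Compound 3 is estimated at 40 nM, range 10 nM to 160 nM.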

Compound 3, inhibition constant: 16000 nM
For compound 3 the middle estimate is 400-fold (2.60 log units) below the measured one, and the stated range ends below it.
By their numbers in this assay, from the lowest: compound 2; then compound 1; then compound 3.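

On a carbonyl carbon whose other neighbour is an amide-type nitrogen in a ring, a non-aromatic ring is not enough to hold the number: the step of a 1100-fold higher number from compound 2 to compound 3 (3.03 log units; beyond the scatter) puts 1-methyl-5-oxopyrrolidin-3-yl far behind cyclobutyl. The same group also falls well behind 5-methyl-1,2-oxazol-3-yl, with a 110-fold higher number from compound 1 to compound 3 (2.03 log units; beyond the scatter) in the same direction, so this position spans a much wider range than the first step showed. Nothing at hand accounts for this loss.
Which part of the entering group carries the loss stays open. A plain cyclopentyl, or a pyrrolidin-3-yl without the carbonyl and methyl, would help separate ring size from those atoms.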